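This account rests on a few compounds, and the source may have more. Where it says the series, first, only, none or still open, it means among the compounds named here.

In a functional assay on HEK293 cells for antagonist activity at transient receptor potential M8 protein (Canis lupus familiaris), read by FLIPR and calcium flux (on this read-out lower numbers stand for stronger inhibition and higher numbers for weaker inhibition), compound 1 `FC(F)(F)c1ccccc1-c1ccc2[nH]c(C3=NOC4(CCCCC4)C3)nc2c1` gives 3.1 nM. Compound 2 `FC(F)(F)Oc1ccccc1-c1ccc2[nH]c(C3=NOC4(CCCCC4)C3)nc2c1` gives 1.1 nM, and compound 3 `Fc1cccc(OC(F)(F)F)c1-c1ccc2[nH]c(C3=NOC4(CCCCC4)C3)nc2c1` gives 0.8 nM. The two cores differ by trifluoromethyl in place of trifluoromethoxy on an aromatic carbon, and that change brings a 2.8-fold lower number from compound 1 to compound 2 (0.45 log units; beyond the scatter). Compound 3 carries fluoro in place of hydrogen on an aromatic carbon, which gave a 1.4-fold lower number from compound 2 to compound 3 (0.14 log units; within the scatter). Compound 4 `Fc1cc(-c2ccccc2C(F)(F)F)cc2nc(C3=NOC4(CCCCC4)C3)[nH]c12` has not yet been measured in this assay. It differs from compound 1 by fluoro in place of hydrogen on an aromatic carbon. Within the data shown here, this is the same kind of change as the one from compound 2 to compound 3, but not the same: there the place was on a six-membered aromatic ring of carbon only, ortho to a large group and meta to a trifluoromethoxy group, whereas in compound 4 the ring is part of a fused or bridged system of two rings, with the fluoro ortho to a fused ring, meta to a 2-(trifluoromethyl)phenyl group and meta to a fused ring. Among the measured compounds shown here, the only precedent, the step in compound 3 of a 1.4-fold lower number from compound 2 to compound 3 (0.14 log units; within the scatter), stayed within the scatter, and the different surroundings give no further guide. Compound 4 is therefore expected to show a 1.2-fold lower number from compound 1 to compound 4 (0.09 log units; within the scatter). Compound 4 is thus estimated at 2.5 nM, between 1 nM and 6.5 nM.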

Compound 4, half-maximal inhibitory concentration: 2.2 nM
The estimate for compound 4 lay 1.1-fold (0.06 log units) above the measured number; the range from low to high includes it.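

In this assay, fluoro in place of hydrogen on the core of compound 1 gave a 1.4-fold lower number from compound 1 to compound 4 (0.15 log units; within the scatter), so on this core the change cannot be told apart from repeat measurement. Set beside the earlier case, the change reads the same on the two cores, with no difference between its steps: the same change on two cores in this assay, a 1.4-fold lower number (0.14 log units; within the scatter) from compound 2 to compound 3 and a 1.4-fold lower number (0.15 log units; within the scatter) from compound 1 to compound 4, 1.0-fold (0.01 log units) apart, within the scatter of two such steps This shows only that the change stayed within the scatter in both pairs, at two different places, and it does not show that fluoro has a real effect of its own on this read-out, nor that the same would hold on any further core in the series.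

The compounds shown leave open whether another group at the place taken by fluoro in compound 4, such as chloro, methoxy or an amine, would move the number beyond the scatter. On these data alone, it also remains open how fluoro would fare on a core carrying a nitrile or a carboxylic acid in place of the trifluoromethyl group.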